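This account rests on a few compounds, and the source may have more. Where it says the series, first, only, none or still open, it means among the compounds named here.

Measured compounds:
Compound 1, `CC(C)c1noc(N2CCN(C(=O)[C@@H]3CCCN(S(=O)(=O)c4ccc(S(=O)(=O)C(C)C)cc4)C3)CC2)n1`: 30 nM
Compound 2, `CCN(CC)S(=O)(=O)c1ccc(S(=O)(=O)N2CCC[C@@H](C(=O)N3CCN(c4nc(C(C)C)no4)CC3)C2)cc1`: 30 nM

Compound 2 and compound 1 share a core and differ only at the sulfonyl sulfur, where compound 2 carries a diethylamino group. In a functional assay on MIA PaCa-2 cells (Homo sapiens) for inhibition, read by MTT assay, with a stated time of 3 days (on this read-out higher numbers stand for weaker inhibition and lower numbers for stronger inhibition), compound 2 gives 30 nM, level with compound 1 within the scatter, as the step of no change at the digits printed from compound 1 to compound 2 (within the scatter) shows. Compound 3, `CCNS(=O)(=O)c1ccc(S(=O)(=O)N2CCC[C@@H](C(=O)N3CCN(c4nc(C(C)C)no4)CC3)C2)cc1`, is not yet measured; it differs from compound 2 by hydrogen in place of ethyl on a sulfonamide nitrogen. Within the data shown here, only one measured step bears on this region, the step from isopropyl to diethylamino on the sulfonyl sulfur, which was no change at the digits printed from compound 1 to compound 2 (within the scatter); no measured pair removes one ethyl from the sulfonamide nitrogen. Among the measured compounds shown here, since the one change at that position left this assay unmoved, compound 3 is expected to stay close to compound 2, with the step of a 1.2-fold higher number from compound 2 to compound 3 (0.07 log units; within the scatter) estimated as no change beyond the scatter. Compound 3 is therefore expected to give about 35 nM in this assay, with a range from 12 nM to 100 nM.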

Compound 3, half-maximal inhibitory concentration: 200 nM
For compound 3 the middle estimate is 5.7-fold (0.76 log units) below the measured one; measured number above the stated range.
By their numbers in this assay, from the lowest: compounds 1 and 2 (each within the scatter of the next); then compound 3.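

The position on the sulfonyl sulfur is not indifferent to change after all: in this assay, taking one ethyl off the sulfonamide nitrogen gives a 6.7-fold higher number from compound 2 to compound 3 (0.82 log units; beyond the scatter), whereas the earlier swap of isopropyl for diethylamino left the number level. Ethylamino in place of isopropyl likewise gives a 6.7-fold higher number from compound 1 to compound 3 (0.82 log units; beyond the scatter), so a sulfonamide at this place is not enough to hold the number, and the two nitrogen substituents differ in what they allow. Nothing measured here accounts for the loss.

The compounds shown leave open whether the step follows the hydrogen now on the sulfonamide nitrogen or the ethyl that left it, a question that ethylmethylamino, which keeps two carbon substituents, would bear on. They also leave open how an unsubstituted amino group or dipropylamino would read at this position.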